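A cyano group on the ring of compound 3

This account rests on a few compounds, and the source may have more. Where it says the series, first, only, none or still open, it means among the compounds named here.

compound 1 `COC[C@@H]1CCCN1S(=O)(=O)c1ccc(Cl)c(COc2cccc3c(C(F)(F)F)cc(C)nc23)c1Cl` gives 1620 mL/min/kg
compound 2 `Cc1cc(C(F)(F)F)c2cccc(OCc3c(Cl)ccc(S(=O)(=O)N4CCCC4)c3Cl)c2n1` gives 967 mL/min/kg
compound 3 `Cc1cc(C(F)(F)F)c2cccc(OCc3c(Cl)ccc(S(=O)(=O)N4CCCCC4)c3Cl)c2n1` gives 1000 mL/min/kg

In an ADME assay on microsomes (Mus musculus) for metabolic stability (a lower number here means slower removal, a higher number faster removal of the compound), compound 3 gives 1000 mL/min/kg and lies within the scatter of compound 1 and compound 2. Compound 4 `Cc1cc(C(F)(F)F)c2cccc(OCc3c(Cl)ccc(S(=O)(=O)N4CCC(C#N)CC4)c3Cl)c2n1` carries cyano in place of hydrogen on a saturated ring carbon. Among the measured compounds shown here, no measured step adds a cyano group. The nearest guides, both changing the ring on the sulfonyl sulfur, are a 1.0-fold higher number from compound 2 to compound 3 (0.01 log units; within the scatter) and a 1.6-fold lower number from compound 1 to compound 3 (0.21 log units; within the scatter) in size. Neither goes beyond the scatter, so no step beyond it is expected here, though the new group leaves real uncertainty. The expected step is a 1.3-fold lower number from compound 3 to compound 4 (0.12 log units; within the scatter) by this estimate. Compound 4 is estimated at 750 mL/min/kg with an expected range from 300 mL/min/kg to 1400 mL/min/kg in this measurement.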

Compound 4, clearance: 1720 mL/min/kg
The estimate for compound 4 lay 2.3-fold (0.36 log units) below the measured number; the measured number lies above the stated range.
By their numbers in this assay, from the lowest: compounds 2, 3, 1 and 4 (each within the scatter of the next).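

In this assay the cyano group on this saturated ring carbon, three ring bonds from the ring nitrogen, gives a 1.7-fold higher number from compound 3 to compound 4 (0.24 log units; within the scatter) and so brings no step beyond the scatter at this position. Against the other two rings on the sulfonyl sulfur, 4-cyanopiperidin-1-yl gives a 1.8-fold higher number from compound 2 to compound 4 (0.25 log units; within the scatter) and a 1.1-fold higher number from compound 1 to compound 4 (0.03 log units; within the scatter) and so stays level with both. No measurement here offers an explanation for these numbers.

From the compounds shown here alone, whether an amine or a carboxylic acid on the same ring carbon would give a step beyond the scatter remains open.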